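Bromo in Place of Chloro on the Pendant Ring

The source may report more compounds than this note shows. Statements on the series, on what has been measured and on what is new or still open speak of the compounds shown alone.

Of the compounds shown here, three sharing one core have been measured in a functional assay on CHO cells for antagonist activity at metabotropic glutamate receptor 5 (Rattus norvegicus), read by calcium flux; a higher number here means a weaker inhibitor, a lower number a stronger inhibitor. Compound 1 `Cc1cccc(-c2ccc3ccc(C)nc3n2)c1` carries a methyl on its pendant aromatic ring and gives 277 nM. Compound 2 `Cc1ccc2ccc(-c3cc(F)cc(F)c3)nc2n1` carries two fluorines on that ring and gives 181 nM. Compound 3 `Cc1ccc2ccc(-c3cccc(Cl)c3)nc2n1` carries a single chloro and gives 177 nM.

Within the data shown here, compound 3 shows the lowest of the three numbers, but none of the gaps separating it from the others exceeds the scatter: compound 2 sits almost on top of it, and the only single-point step, a 1.6-fold lower number from compound 1 to compound 3 (0.19 log units; within the scatter), is small. So compound 3 and its neighbours cannot be ranked with confidence.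

Compound 4 `Cc1ccc2ccc(-c3cccc(Br)c3)nc2n1` is the next member of the series and has not yet been measured. It differs from compound 3 by bromo in place of chloro on an aromatic carbon. Among the measured compounds shown here, the one step that bears on this change is the halogen-for-methyl exchange from compound 1 to compound 3, which stayed within the scatter. A move from one halogen to the next is expected to be at least as modest, so the estimated step of a 1.1-fold lower number from compound 3 to compound 4 (0.04 log units; within the scatter) is not expected to rise above the scatter in either direction. Compound 4 is therefore estimated at 160 nM, with a range from 70 nM to 360 nM in this assay.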

Compound 4, half-maximal inhibitory concentration: 47.9 nM
Compound 4: middle estimate off by 3.3-fold (0.52 log units), on the high side; the whole stated range lies above it.
By their numbers in this assay, from the lowest: compound 4; then compounds 3, 2 and 1 (each within the scatter of the next).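

On the pendant ring, at this aromatic carbon meta to a large group, this assay does distinguish one halogen from the next: a 3.7-fold lower number from compound 3 to compound 4 (0.57 log units; beyond the scatter) is a step beyond the scatter, whereas the exchange of methyl for chloro, a 1.6-fold lower number from compound 1 to compound 3 (0.19 log units; within the scatter), stayed within it. Measured against the methyl, the bromo gives a 5.8-fold lower number from compound 1 to compound 4 (0.76 log units; beyond the scatter), so this place on the ring responds to the group it carries more clearly than the first three compounds could show. The change is a single heavy atom for a single heavy atom, with no difference in rings, hydrogen-bond donors, hydrogen-bond acceptors or net charge, and nothing measured here bears on the reason for the gap between chloro and bromo.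

As far as these compounds go, whether iodo, trifluoromethyl or methoxy at this same place would match bromo, or fall back towards chloro, remains open. Among these compounds, also open is whether bromo would give a comparable step at another carbon of the pendant ring, since the chloro and bromo pair offers only this one comparison.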